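Methoxy to hydroxymethyl on the amine chain of compound 2

The source may hold more compounds than are shown below. What is called first, only, known or untested is meant among the compounds shown, and "the series" means these compounds.

In a functional assay on Caco-2 cells (Homo sapiens) for activation, read by fluorescence, tested at 1 uM (on this read-out lower numbers stand for a stronger effect and higher numbers for a weaker effect at the one concentration tested), compound 1 `COCCCN1C(/C=C/c2ccc(O)cc2)=CC(=O)CC1c1ccc(O)cc1` gives 99% and compound 2 `COCCNC(=C\C(=O)/C=C/c1ccc(O)cc1)/C=C/c1ccc(O)cc1` gives 94.9%. Compound 2 holds the lowest of the two numbers, yet its nearest neighbour, compound 1, sits within the scatter, so the two read the same. Compound 3 `O=C(/C=C(/C=C/c1ccc(O)cc1)NCCCO)/C=C/c1ccc(O)cc1` is not yet measured in this assay. It differs from compound 2 by hydroxymethyl in place of methoxy on a saturated chain carbon, two bonds along the chain from an amine nitrogen. Going by the values given here, no step between measured compounds is known for this kind of change, so nothing beyond the scatter is expected: the expected step is a number 1.1 percentage points higher from compound 2 to compound 3 (within the scatter). Compound 3 is therefore estimated at 96%, with a range of 87% to 104%.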

Compound 3, a percentage reported as activity, at one concentration (the size of the read-out at that concentration, not a potency): 94.1%
Estimate against measurement, compound 3: 1.9 percentage points above; the measured number falls inside the stated range.
By their numbers in this assay, from the lowest: compounds 3, 2 and 1 (each within the scatter of the next).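

In this assay, hydroxymethyl in place of methoxy on a saturated chain carbon, two bonds along the chain from an amine nitrogen, gives a number 0.8 percentage points lower from compound 2 to compound 3 (within the scatter). Going by these compounds alone, this is the first step read for this change, and the added hydrogen-bond donor leaves the read-out within the scatter at this position. No supporting data bear on this result.

Open, going by these compounds, is whether a carboxylic acid or an amine in place of the hydroxymethyl, or a longer chain, would move the read-out beyond the scatter. With a single concentration tested, the pair also gives no potency.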